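The source may report more compounds than this note shows. Statements on the series, on what has been measured and on what is new or still open speak of the compounds shown alone.

Measured in a functional assay on PC-3 cells (Homo sapiens) for cytotoxicity, read by MTT assay, with a stated time of 72 h; on this read-out higher numbers stand for weaker inhibition and lower numbers for stronger inhibition:
Compound 1 `[O-][n+]1nc(NCOCc2ccc(Cl)cc2)[n+]([O-])c2ccccc21` gives 5760 nM.
Compound 2 `COc1ccc(COCNc2n[n+]([O-])c3ccccc3[n+]2[O-])cc1` gives 14500 nM.
Compound 3 `COCNc1n[n+]([O-])c2ccccc2[n+]1[O-]` gives 7510 nM.

Compound 1 has the lowest number of the three; it sits close to compound 3, as a 1.3-fold higher number from compound 1 to compound 3 (0.12 log units; within the scatter) lies within the scatter, and apart from compound 2, with a 2.5-fold higher number from compound 1 to compound 2 (0.40 log units; beyond the scatter) beyond it. Compound 4 `[O-][n+]1nc(NCOCc2ccccc2)[n+]([O-])c2ccccc21` differs from compound 1 by hydrogen in place of chloro on an aromatic carbon. For the measured compounds named here, two steps bear on this. Removing the whole 4-chlorophenyl gives a 1.3-fold higher number from compound 1 to compound 3 (0.12 log units; within the scatter); exchanging the chloro for methoxy gives a 2.5-fold higher number from compound 1 to compound 2 (0.40 log units; beyond the scatter). Both steps in this assay move upward, one within and one just beyond the scatter, so removing the chloro alone should give at most a small upward move. For compound 4 the expected step is a 1.2-fold higher number from compound 1 to compound 4 (0.08 log units; within the scatter). Compound 4 is thus estimated at 7000 nM, within 3500 nM to 14000 nM.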

Compound 4, half-maximal inhibitory concentration: 13400 nM
Beside the measured number, compound 4's estimate is 1.9-fold (0.28 log units) below it, and the stated range covers the measured number.
By their numbers in this assay, from the lowest: compounds 1, 3, 4 and 2 (each within the scatter of the next, the first and the last beyond it).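

In this assay, hydrogen in place of chloro alone is a step beyond the scatter (a 2.3-fold higher number from compound 1 to compound 4 (0.37 log units; beyond the scatter)), so the chloro para to a large group separates compound 1 from compound 4. Hydrogen and methoxy at this place are not told apart (a 1.1-fold lower number from compound 2 to compound 4 (0.03 log units; within the scatter)), and phenyl in place of hydrogen on the chain stays within the scatter (a 1.8-fold higher number from compound 3 to compound 4 (0.25 log units; within the scatter)). Nothing at hand gives a reason for the chloro step. Open, on these data alone, is whether fluoro, bromo or an amine at this place would read like chloro or like hydrogen.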